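This account rests on a few compounds, and the source may have more. Where it says the series, first, only, none or still open, it means among the compounds named here.

Working notes on the series, read in a functional assay on J774 cells (Mus musculus) for cytotoxicity, read by resazurin assay; a higher number here means a weaker inhibitor, a lower number a stronger inhibitor. Compound 1 (`OCCCCCC(O)c1ccc(-c2ccc(Br)cc2)cc1`) gives 20000 nM, compound 2 (`Cc1ccc(-c2ccc(C(O)CCCCCO)cc2)cc1`) gives 22000 nM, and compound 3 (`OCCCCCC(O)c1ccc(-c2ccc(Cl)cc2)cc1`) gives 17000 nM. Compound 3 stands level with the other two on these numbers, with a 1.2-fold lower number from compound 1 to compound 3 (0.07 log units; within the scatter) and a 1.3-fold lower number from compound 2 to compound 3 (0.11 log units; within the scatter).

The next step leads to compound 4 (`OCCCCCC(O)c1ccc(-c2ccc(OC(F)(F)F)cc2)cc1`), which has not yet been measured. The change is trifluoromethoxy in place of chloro on an aromatic carbon, para to a large group: trifluoromethoxy in place of chloro on an aromatic carbon.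

The measured steps that bear on this are the exchanges among bromo, methyl and chloro at that same place. Besides the two steps above, these include a 1.1-fold higher number from compound 1 to compound 2 (0.04 log units; within the scatter). Among the measured compounds shown here, none of the three leaves the scatter, so the series so far shows no response to the exchanges tried at this place. For the measured compounds named here, no measured compound carries trifluoromethoxy, however, so this reading is an extrapolation and the range is kept wide.

No step beyond the scatter is therefore expected in this assay, and no firm direction can be given. The estimated step is a 1.1-fold lower number from compound 3 to compound 4 (0.05 log units; within the scatter). For compound 4 the expected value is 15000 nM, with an estimated range from 7000 nM to 30000 nM.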

Compound 4, half-maximal inhibitory concentration: 14000 nM
The estimate for compound 4 lay 1.1-fold (0.03 log units) above the measured number; the measured number falls inside the stated range.
By their numbers in this assay, from the lowest: compounds 4, 3, 1 and 2 (each within the scatter of the next).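

In this assay, the exchange of chloro (1 heavy atom, 0 hydrogen-bond acceptors) for trifluoromethoxy (5 heavy atoms, 1 hydrogen-bond acceptor) on an aromatic carbon, para to a large group, gives a 1.2-fold lower number from compound 3 to compound 4 (0.08 log units; within the scatter) and so extends the flat reading at this place to a group with more heavy atoms and a hydrogen-bond acceptor. The comparisons with the other two groups read the same way, with a 1.6-fold lower number from compound 2 to compound 4 (0.20 log units; within the scatter) and a 1.4-fold lower number from compound 1 to compound 4 (0.15 log units; within the scatter) together showing that bromo, methyl, chloro and trifluoromethoxy all stand within the scatter of one another, and none of compounds 1, 2, 3 or 4 goes against this. No supporting measurement is available to account for this lack of response at this place.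

On these data alone, whether a charged group such as an amine or a carboxylic acid at this place would give a step beyond the scatter remains open. Also open, as far as these compounds go, is whether the reading stays flat when the shared core changes elsewhere, for instance with a longer chain in place of the hydroxyl-bearing chain common to all four compounds.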